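Swapping Trifluoromethyl for (Trifluoromethyl)sulfanyl in a Urea

This account rests on a few compounds, and the source may have more. Where it says the series, first, only, none or still open, it means among the compounds named here.

compound 1 `CSc1ccc(NC(=O)Nc2cc(C)nc3ccccc23)cc1`: 16000 nM
compound 2 `Cc1cc(NC(=O)Nc2ccc(C(F)(F)F)cc2)c2ccccc2n1`: 23000 nM

In an ADME assay on HepG2 cells (Homo sapiens) for cytotoxicity, with a stated time of 72 h (on this read-out higher numbers stand for an effect only at larger amounts of compound and lower numbers for an effect already at smaller amounts), compound 2 gives the higher of the two numbers shown, though the step of a 1.4-fold higher number from compound 1 to compound 2 (0.16 log units; within the scatter) lies within the scatter, so the two compounds are not separated. Compound 3 `Cc1cc(NC(=O)Nc2ccc(SC(F)(F)F)cc2)c2ccccc2n1` differs from compound 2 by (trifluoromethyl)sulfanyl in place of trifluoromethyl on an aromatic carbon. Among the compounds with values here, the one measured step, from a methylsulfanyl group to a trifluoromethyl group, also replaced a group on an aromatic carbon and stayed within the scatter. Compound 3 is therefore expected to show no step beyond the scatter, a 1.2-fold lower number from compound 2 to compound 3 (0.06 log units; within the scatter). For compound 3 the estimated value is 20000 nM, expected to fall between 8000 nM and 50000 nM.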

Compound 3, half-maximal effective concentration: 20000 nM
Compound 3: middle estimate and measured number agree at the digits printed; measured number inside the range.
By their numbers in this assay, from the lowest: compounds 1, 3 and 2 (each within the scatter of the next).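

In this assay, (trifluoromethyl)sulfanyl in place of trifluoromethyl gives a 1.2-fold lower number from compound 2 to compound 3 (0.06 log units; within the scatter), and trifluoromethyl in place of methyl on the sulfur gives a 1.3-fold higher number from compound 1 to compound 3 (0.10 log units; within the scatter). On this aromatic carbon, para to a large group, the three sulfur- or fluorine-bearing groups shown are therefore not told apart by this read-out. Nothing available explains why their numbers lie so close. From the compounds shown here alone, whether an amine or a carboxylic acid at the same place would give a step beyond the scatter remains open.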